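The source may report more compounds than this note shows. Statements on the series, on what has been measured and on what is new or still open speak of the compounds shown alone.

Compound 3 `CCOCC(C)Oc1cccc2ccc(N)nc12` is one of three compounds already tested in an assay on cells with melanin-concentrating hormone receptor 1 (Homo sapiens) as the target, read by radioligand binding; a lower number here means a stronger inhibitor, a higher number a weaker inhibitor. Within that set, compound 3 gives 1070 nM, the highest of the two numbers reported. The nearest comparator, compound 1 `CC1CCCCC1Oc1cccc2ccc(N)nc12`, gives 32 nM, a gap well beyond the usual scatter. The third compound, compound 2 `CC(CC(C)(C)C)Oc1cccc2cccnc12`, does not come with a number at all; in this assay compound 2 reaches only the limit of > 2000 nM, and one of the three results sits at that limit (the limit of > 2000 nM in this assay, at which 1 of the 3 values shown sits). Compound 2 also lacks the amino group that compounds 1 and 3 share on their core, so no single-point comparison with it is available.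

The next compound, compound 4 `CC(C)C(C)Oc1cccc2ccc(N)nc12`, is a close relative of compound 3: isopropyl in place of ethoxymethyl on a saturated chain carbon bound to an oxygen on an aromatic ring and a saturated chain carbon. The remaining structure, the aromatic core with its amino group and the oxygen linking the saturated chain to it, is kept. Compound 4 thus carries a branched hydrocarbon chain on the oxygen, like compound 1, rather than the oxygen-containing chain of compound 3.

Compound 4 is therefore expected to sit between compound 3 and compound 1, with an estimated step of a 7.1-fold lower number from compound 3 to compound 4 (0.85 log units; beyond the scatter) toward a stronger inhibitor, beyond the scatter. The estimate for compound 4 in this assay is 150 nM, within a range of 40 nM to 600 nM.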

Compound 4, half-maximal inhibitory concentration: 199 nM
For compound 4 the middle estimate is 1.3-fold (0.12 log units) below the measured one; the range from low to high includes it.
By their numbers in this assay, from the lowest: compound 1; then compound 4; then compound 3. At a limit, above all of these: compound 2.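

This pair is the first among the compounds shown that differ in one place only, so it gives the first direct reading of the group on the saturated chain carbon bound to the oxygen. In this assay putting isopropyl in place of ethoxymethyl gives a 5.4-fold lower number from compound 3 to compound 4 (0.73 log units; beyond the scatter) and so shows that this group alone moves the result by more than the scatter, with the shared core, its amino group and the linking oxygen all kept. The change swaps a group that has an oxygen and a hydrogen-bond acceptor for an all-carbon group with one heavy atom fewer, and no measurement shown here explains why the number falls.

One pair cannot tell whether the loss of the chain oxygen or the change in the shape and size of the group matters more, as both change together in this single step. A butyl chain, a longer hydrocarbon chain, or an amine or a hydroxyl group at this same place would help to separate these two readings and show how far the trend extends.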